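A Methylphenyl Variant Against an Untroubled Cytotoxicity Ceiling

The source may hold more compounds than are shown below. What is called first, only, known or untested is meant among the compounds shown, and "the series" means these compounds.

Compound 1 `Cc1nc(-c2cccnc2)sc1-c1nnc(-c2ccc(Br)cc2)o1` has been examined in an ADME assay on HCT-116 cells (Homo sapiens) for cytotoxicity, read by MTT assay (a lower number here means that less compound is tolerated, a higher number that more compound is tolerated), where compound 1 gives only a limit, > 100 ug/mL. Its two neighbours sit at the same ceiling. Compound 2 `Cc1ccc(-c2nnc(-c3sc(-c4cccnc4)nc3C)o2)cc1` gives a limit of > 100 ug/mL in this assay. Compound 3 `Cc1nc(-c2cccnc2)sc1-c1nnc(-c2ccccc2)o1` likewise gives a limit of > 100 ug/mL in this assay. Because all three stand at the limit of > 100 ug/mL in this assay, at which 3 of the 3 values shown sit, none of the steps among them can be sized: a step that the two limits leave unreadable from compound 1 to compound 2, a step that the two limits leave unreadable from compound 1 to compound 3 and a step that the two limits leave unreadable from compound 2 to compound 3 are each unreadable. Compound 4 `Cc1ccccc1-c1nnc(-c2sc(-c3cccnc3)nc2C)o1` is not yet measured. It differs from compound 1 by 2-methylphenyl in place of 4-bromophenyl on an aromatic carbon. The measured steps that bear on it, bromo giving way to methyl and to hydrogen on an aromatic carbon, were all hidden by the limit, so neither a direction nor a size can be read from them. Compound 4 is therefore expected to remain at the ceiling, and the step that the limit leaves unreadable from compound 1 to compound 4 is expected to be none beyond the scatter. The estimate for compound 4 in this assay is 150 ug/mL, with a range from 60 ug/mL to 400 ug/mL.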

Compound 4, half-maximal cytotoxic concentration: > 100 ug/mL
Compound 4: no number, only a limit; the forecaster's own chance of this, stated with the estimate: 85%; the middle value is on the limit's open side.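

Compound 4 joins compound 1, compound 2 and compound 3 at the ceiling of this assay, so none of the steps to compound 4 can be read: the limit of > 100 ug/mL in this assay, at which 4 of the 4 values shown sit.

The compounds shown leave open whether these aromatic groups differ at all in this assay, since the true tolerated concentration of each compound remains unknown.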